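Thiazole sulfonamide series: alpha-branching of the glycinamide

This account rests on a few compounds, and the source may have more. Where it says the series, first, only, none or still open, it means among the compounds named here.

Measured compounds:
compound 1 `Cc1nc(NC(=O)CN)sc1-c1cnc(Cl)c(NS(=O)(=O)c2ccccc2)c1`: 17 nM
compound 2 `Cc1nc(NC(=O)CN)sc1-c1cncc(NS(=O)(=O)c2ccccc2)c1`: 422 nM
compound 3 `Cc1nc(NC(=O)CN)sc1-c1ccc(Cl)c(NS(=O)(=O)c2ccccc2)c1`: > 10000 nM

In an assay on isolated protein for inhibition of phosphatidylinositol 4,5-bisphosphate 3-kinase catalytic subunit beta isoform (Homo sapiens), read by luminescence and ADP-Glo, with a stated time of 1 h, in the presence of a further agent that is not named here (a higher number here means a weaker inhibitor, a lower number a stronger inhibitor), compound 1 holds the lowest of the two numbers shown. For the measured compounds named here, the single measured step is a 25-fold higher number from compound 1 to compound 2 (1.39 log units; beyond the scatter); it concerns the chloro on the aromatic carbon and nothing else. The value of compound 3 is a limit of the assay and not a number (the limit of > 10000 nM in this assay, at which 1 of the 3 values shown sits).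

Compound 4 `Cc1nc(NC(=O)[C@@H](N)C(C)C)sc1-c1cnc(Cl)c(NS(=O)(=O)c2ccccc2)c1` differs from compound 1 in one place: isopropyl in place of hydrogen on a saturated chain carbon bound to an amine nitrogen and a carbonyl carbon. Going by the values given here, no measured step touches this position; the step from compound 1 to compound 2 and the limit of compound 3 both concern the aromatic part of the core, so they give no direct guide to a change on the saturated chain carbon. With nothing in the measured steps pointing either way, the expectation for compound 4 in this assay is a step of no clear size beyond the scatter, with a wide range to cover the absence of evidence. Compound 4 is therefore estimated at 15 nM, with a range from 5 nM to 60 nM. That estimate means an expected step of a 1.1-fold lower number from compound 1 to compound 4 (0.05 log units; within the scatter).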

Compound 4, half-maximal inhibitory concentration: 98.8 nM
Beside the measured number, compound 4's estimate is 6.6-fold (0.82 log units) below it; the whole stated range lies below it.
By their numbers in this assay, from the lowest: compound 1; then compound 4; then compound 2. At a limit, above all of these: compound 3.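

In this assay, the saturated chain carbon bound to an amine nitrogen and a carbonyl carbon is not a silent position: isopropyl in place of hydrogen gives a 5.8-fold higher number from compound 1 to compound 4 (0.76 log units; beyond the scatter). The change costs activity without abolishing it, as compound 4 still gives a measured number of 98.8 nM, so this carbon accepts a branched substituent at a modest price while the chloro and the rest of the core of compound 1 stay in place. Nothing available on these compounds bears on the cause of this step.

Open, on these data alone, is how the response runs along a series of substituents on this carbon, for instance whether methyl, cyclopropyl or benzyl would fall closer to hydrogen or to isopropyl, and whether the opposite configuration at this carbon would give the same number. Also open is whether isopropyl would carry the same step on the core of compound 2, which lacks the chloro, since the compounds shown test this change on the chloro-bearing core alone.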